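The source may hold more compounds than are shown below. What is called first, only, known or untested is meant among the compounds shown, and "the series" means these compounds.

Compound 1 `CCN1C(=O)c2c(nc(C(N)=O)n2Cc2ccc(O)c(Br)c2)N2C1=N[C@@H]1CCC[C@@H]12` gives 3.03 in a physicochemical assay for lipophilicity, measured as octanol-water partition; on this read-out lower numbers stand for lower lipophilicity and higher numbers for higher lipophilicity. Compound 2 `CCN1C(=O)c2c(nc(C(N)=O)n2Cc2ccc(O)c(Cl)c2)N2C1=N[C@@H]1CCC[C@@H]12` gives 2.76 in the same assay. The change from compound 1 to compound 2, (chloro in place of bromo on an aromatic carbon), made a step of a number 0.27 log units lower from compound 1 to compound 2 (within the scatter).

Compound 3 `CCOc1nc2c(n1Cc1ccc(OC)c(Br)c1)C(=O)N(CC)C1=N[C@@H]3CCC[C@@H]3N12` gives 4.93, the highest of the three numbers; the difference between its core and that of compound 1 is not broken down here. Compound 4 `CCOc1nc2c(n1Cc1ccc(OC)c(Cl)c1)C(=O)N(CC)C1=N[C@@H]3CCC[C@@H]3N12` is not yet measured. It differs from compound 3 by chloro in place of bromo on an aromatic carbon. Among the measured compounds shown here, this is the same kind of change as the one from compound 1 to compound 2, but not the same: there the chloro stands ortho to a hydroxy group, here ortho to a methoxy group.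

For the measured compounds named here, compound 4 is expected to move from compound 3 by about a number 0.27 log units lower from compound 3 to compound 4 (within the scatter), a step of similar size to the earlier one, because the only measured example of this kind of change, a number 0.27 log units lower from compound 1 to compound 2 (within the scatter), stayed within the scatter. Compound 4 is therefore estimated at 4.66, likely between 4.3 and 5.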

Compound 4, partition coefficient: 4.66
The estimate for compound 4 equals the measured number at the digits printed; the range from low to high includes it.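

In this assay, the change from 3-bromo-4-methoxyphenyl to 3-chloro-4-methoxyphenyl gave a number 0.27 log units lower from compound 3 to compound 4 (within the scatter) on one core and the same kind of change gave a number 0.27 log units lower from compound 1 to compound 2 (within the scatter) on the other, so in these two pairs it carried from one core to the other with a step of matching size, even though the neighbouring group is hydroxy in one pair and methoxy in the other. Both steps lie within the scatter, so they do not show that chloro in place of bromo has a real effect on this read-out, and two pairs set no rule for other cores in the series. Nothing given here bears on why the two steps agree.

From the compounds shown here alone, whether the match would hold with fluoro or a nitrile in place of bromo stays open. So does what an amine or a carboxylic acid in place of the ethoxy group of compound 4 would do to the read-out.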